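Chain length, then a new group on the core

A few compounds are considered here, and "the series" means these few. Any claim that something is new, unique, unknown or untested is made for them only; others in the source may bear on it.

- compound 1 `CCc1nc(CO)c(C(=O)O)n1Cc1ccc(-c2ccccc2C(=O)O)cc1`: 0.27 mg/kg
- compound 2 `CCCc1nc(CO)c(C(=O)O)n1Cc1ccc(-c2ccccc2C(=O)O)cc1`: 0.069 mg/kg
- compound 3 `CCCCc1nc(CO)c(C(=O)O)n1Cc1ccc(-c2ccccc2C(=O)O)cc1`: 0.22 mg/kg

These three compounds share one core and differ only in the length of one saturated chain. In a functional assay on the whole organism for inhibition, with Rattus norvegicus as the target (a lower number here means that less compound is needed, a higher number that more compound is needed for the effect), compound 3, which carries the butyl group, gives 0.22 mg/kg. Its nearest neighbour in the set is close, a 1.2-fold lower number from compound 1 to compound 3 (0.09 log units; within the scatter), while the furthest stands clearly apart, a 3.2-fold higher number from compound 2 to compound 3 (0.50 log units; beyond the scatter).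

The next compound, compound 4 `CCCCc1nc(Cl)c(C(=O)O)n1Cc1ccc(-c2ccccc2C(=O)O)cc1`, keeps the butyl group but changes a different place: chloro in place of hydroxymethyl on an aromatic carbon. Among the measured compounds shown here, none of the measured steps touches that place, since all of them alter the chain. They show only how far this assay has moved within this small set, and the largest move is modest: a 3.9-fold lower number from compound 1 to compound 2 (0.59 log units; beyond the scatter). For the measured compounds named here, no measured compound shows what chloro does here, so the data give no direction. The central expectation is therefore no step beyond the scatter, with a wide margin on either side. The expected change is a 1.1-fold higher number from compound 3 to compound 4 (0.06 log units; within the scatter). For compound 4 the estimated value is 0.25 mg/kg, with an expected range from 0.06 mg/kg to 1 mg/kg.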

Compound 4, dose for 50% inhibition: 0.21 mg/kg
The estimate for compound 4 lay 1.2-fold (0.08 log units) above the measured number; the measured number falls inside the stated range.
By their numbers in this assay, from the lowest: compound 2; then compounds 4, 3 and 1 (each within the scatter of the next).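

Among the compounds shown here, this is the first measured change at this aromatic carbon, and in this assay putting chloro in place of hydroxymethyl gives a 1.0-fold lower number from compound 3 to compound 4 (0.02 log units; within the scatter), so the two compounds cannot be told apart. Hydroxymethyl carries 1 hydrogen-bond donor and 1 hydrogen-bond acceptor, while chloro has 0 of each, so with the butyl group in place this pair shows that the number can stay within the scatter when that donor and acceptor are gone. Nothing measured here explains why the swap leaves the number where it is, and one pair cannot show whether the two groups act alike or whether separate effects happen to cancel out.

The compounds shown leave open whether chloro would also match hydroxymethyl on the propyl chain of compound 2, which gives 0.069 mg/kg, since the chain and this position have so far been varied only one at a time. They also leave open what other groups on this aromatic carbon would do, such as a methyl, an amine or a carboxylic acid, any of which might move the number well beyond the scatter.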